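An Unmeasured Tail Change Judged Against Three Values

A few compounds are considered here, and "the series" means these few. Any claim that something is new, unique, unknown or untested is made for them only; others in the source may bear on it.

Compound 1 `O=C1c2c[n+]([O-])c3ccccc3c2C(=O)c2c1c1ccccc1n2Cc1cn([C@H]2O[C@H](CO)[C@@H](O)[C@H]2O)nn1` in a functional assay on HCT-116 cells (Homo sapiens) for cytotoxicity, read by MTT assay, with a stated time of 72 h (on this read-out lower numbers stand for stronger inhibition and higher numbers for weaker inhibition), gives 710 nM.
Compound 2 `O=C1c2c[n+]([O-])c3ccccc3c2C(=O)c2c1c1ccccc1n2CCCCN1CCNCC1` in this assay gives 700 nM.
Compound 3 `O=C1c2c[n+]([O-])c3ccccc3c2C(=O)c2c1c1ccccc1n2Cc1cn([C@@H]2O[C@H](CO)[C@@H](O)[C@H](O)[C@H]2O)nn1` in this assay gives 130 nM.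

Among these three numbers compound 2 stands second highest; its nearest neighbour is compound 1, whose number lies within the scatter of it, while compound 3 sits beyond the scatter at the lower end. Compound 4 `O=C1c2c[n+]([O-])c3ccccc3c2C(=O)c2c1c1ccccc1n2CCN1CCCCC1` differs from compound 2 by piperidin-1-yl in place of 2-(piperazin-1-yl)ethyl on a saturated chain carbon, two bonds along the chain from an aromatic nitrogen. Going by the values given here, the only measured step, a 5.5-fold lower number from compound 1 to compound 3 (0.74 log units; beyond the scatter), changes the group on an aromatic nitrogen and so does not bear on this change at a saturated chain carbon. With nothing to point a direction, the expectation for compound 4 in this assay is a step of a 1.3-fold higher number from compound 2 to compound 4 (0.11 log units; within the scatter), not beyond the scatter. Compound 4 is therefore estimated at 900 nM, with a range from 300 nM to 3000 nM.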

Compound 4, half-maximal inhibitory concentration: 780 nM
The estimate for compound 4 lay 1.2-fold (0.06 log units) above the measured number, and the stated range covers the measured number.
By their numbers in this assay, from the lowest: compound 3; then compounds 2, 1 and 4 (each within the scatter of the next).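

In this assay, going by these compounds alone, the replacement at this saturated chain carbon gives a 1.1-fold higher number from compound 2 to compound 4 (0.05 log units; within the scatter), the first measured step at this place. The two tails differ in their ring hetero atoms and hydrogen-bond donors, yet this difference leaves the two numbers within the scatter of each other. No supporting measurement bears on why this pair reads so closely.

The step changes the tail's length and its ring together, so the compounds shown do not separate these two changes. From the compounds shown here alone, whether a morpholine ring, a primary amine or a carboxylic acid at the tail end would read the same remains open.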